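Dropping one methoxy from a weakly tested pair

The source may hold more compounds than are shown below. What is called first, only, known or untested is meant among the compounds shown, and "the series" means these compounds.

Compound 1 `COc1cc(/C=C/C(=O)/C=C/c2cccc3ccccc23)ccc1OCc1cn(CCOc2cc(=O)oc3ccccc23)nn1` gives 20%
Compound 2 `COc1ccc(/C=C/C(=O)/C=C/c2ccc(OCc3cn(CCCCCOc4cc(=O)oc5ccccc45)nn3)c(OC)c2)cc1OC` gives "not active" (no number reported)

In a functional assay on PC-3 cells (Homo sapiens) for inhibition, read by sulforhodamine B assay, with a stated time of 48 h, tested at 50 uM (on this read-out higher numbers stand for more inhibition of growth at the one concentration tested and lower numbers for less inhibition of growth), compound 2 has no single number: it is reported as "not active" (no number reported) and no figure comes with it. The next structure is compound 3 `COc1cccc(/C=C/C(=O)/C=C/c2ccc(OCc3cn(CCCCCOc4cc(=O)oc5ccccc45)nn3)c(OC)c2)c1`. The change is hydrogen in place of methoxy on an aromatic carbon and in words it is hydrogen in place of methoxy on an aromatic carbon, 3,4-dimethoxyphenyl to 3-methoxyphenyl. For the measured compounds named here, no measured step shows what this change does, so in this assay a shift beyond the usual scatter is not expected, in either direction. Compound 3 is estimated at 10% with 0% to 25% as its expected range.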

Compound 3, percent growth inhibition at one concentration: "not active" (no number reported)
Compound 3 has no reported number here; the estimate stays without a comparison.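

In this assay, for the compounds shown here, compound 2 and compound 3 both stand as not active without a number, so no step between them can be read. On these data alone, what the methoxy contributes to growth inhibition stays open, and no evidence at hand bears on this result.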